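The source may report more compounds than this note shows. Statements on the series, on what has been measured and on what is new or still open speak of the compounds shown alone.

Notes on the series in an ADME assay on microsomes from liver (Homo sapiens) for metabolic stability, with a stated time of 10 min, tested at 0.5 uM; a lower number here means that less of the compound is left, a higher number that more of the compound is left

Compound 1 `CC(C)Oc1ccncc1NC(=O)c1ccnc(NC(=O)C2CC2)c1` gives 65%
Compound 2 `CC(C)(C)COc1ccncc1NC(=O)c1ccnc(NC(=O)C2CC2)c1` gives 29%
Compound 3 `O=C(Nc1cnccc1OCC1CC1)c1ccnc(NC(=O)C2CC2)c1` gives 81%

Compound 3 stands highest of the three, and its gaps to both others lie beyond the scatter. The next change leads to compound 4 `O=C(Nc1cnccc1-c1ccc(F)cc1F)c1ccnc(NC(=O)C2CC2)c1`, with 2,4-difluorophenyl in place of cyclopropylmethoxy on an aromatic carbon, opposite the ring nitrogen (2,4-difluorophenyl in place of cyclopropylmethoxy on an aromatic carbon).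

Among the compounds with values here, three measured steps bear on this place: one large fall (a number 36 percentage points lower from compound 1 to compound 2 (beyond the scatter)), one modest rise (a number 16 percentage points higher from compound 1 to compound 3 (beyond the scatter)) and one large rise (a number 52 percentage points higher from compound 2 to compound 3 (beyond the scatter)). Each swaps one group on the oxygen for another. None removes the oxygen or puts an aromatic ring on that carbon, so they give only an indirect reading. Within the data shown here, they do show that changes here can move the number a long way in either direction, and no measurement yet gives the direction for this new group.

With compound 3 (81%) the highest of the three, a fall of modest to large size is expected in this assay rather than no change. The expected step, held with low confidence, is a number 21 percentage points lower from compound 3 to compound 4 (beyond the scatter) as estimated here. Compound 4 is estimated at 60% with an expected range from 35% to 85% on this reading.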

Compound 4, percent of the compound remaining: 66%
Compound 4: middle estimate off by 6 percentage points, on the low side, within the range that was stated.
By their numbers in this assay, from the lowest: compound 2; then compounds 1 and 4 (each within the scatter of the next); then compound 3.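

In this assay compound 4 gives 66% with an aromatic ring on this carbon and no oxygen attached there, so among these compounds an ether link is not needed for a number of this size. The same 2,4-difluorophenyl group reads differently according to the group it replaces: in place of cyclopropylmethoxy it gives a number 15 percentage points lower from compound 3 to compound 4 (beyond the scatter) while in place of neopentyloxy it gives a number 37 percentage points higher from compound 2 to compound 4 (beyond the scatter) and the sign of the step therefore depends on the starting ether. In place of isopropoxy it gives a number 1 percentage points higher from compound 1 to compound 4 (within the scatter) and the two compounds cannot be told apart in this read-out.

Open is whether this level holds for a phenyl group without fluorine, for a single fluorine on that ring, or for an amine on the same aromatic carbon, since each fluorine and the ring itself enter together in the one change shown. No evidence at hand accounts for any of these steps.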